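Methoxy in Place of Chloro: A Step Toward an Expected Limit

This account rests on a few compounds, and the source may have more. Where it says the series, first, only, none or still open, it means among the compounds named here.

Compound 1 `S=c1oc(-c2ccc3c(c2)OCCO3)nn1CN1CCN(c2ccc(Cl)cc2)CC1` carries a 4-chlorophenyl on the amine nitrogen in a ring. In a functional assay on SW 1116 cells (Homo sapiens) for antiproliferative activity, read by MTT assay, with a stated time of 48 h (a higher number here means a weaker inhibitor, a lower number a stronger inhibitor), compound 1 gives > 50000 nM, which is a limit of the assay rather than a number. Compound 2 `Fc1ccc(N2CCN(Cn3nc(-c4ccc5c(c4)OCCO5)oc3=S)CC2)cc1` gives > 50000 nM, also a limit. Compound 3 `COc1cccc(N2CCN(Cn3nc(-c4ccc5c(c4)OCCO5)oc3=S)CC2)c1` gives > 50000 nM, again a limit. Among the measured compounds shown here, the steps a step that the two limits leave unreadable from compound 1 to compound 2 and a step that the two limits leave unreadable from compound 1 to compound 3 therefore cannot be sized, and the limit of > 50000 nM in this assay, at which 3 of the 3 values shown sit, is the only evidence available. Compound 4 `COc1ccc(N2CCN(Cn3nc(-c4ccc5c(c4)OCCO5)oc3=S)CC2)cc1` differs from compound 1 by methoxy in place of chloro on an aromatic carbon. With every measured step unreadable, compound 4 is expected to remain at the same limit, a step that the limit leaves unreadable from compound 1 to compound 4. Compound 4 is thus estimated at 80000 nM, ranging from 30000 nM to 300000 nM.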

Compound 4, half-maximal inhibitory concentration: 24200 nM
Compound 4: the middle estimate sits 3.3-fold (0.52 log units) above what was measured, outside the stated range (below it).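

Among the groups shown on this amine nitrogen, only 4-methoxyphenyl gives a readable value: methoxy in place of chloro gives an at least 2.0-fold lower number from compound 1 to compound 4 (0.31 log units; beyond the scatter), and methoxy in place of fluoro gives an at least 2.0-fold lower number from compound 2 to compound 4 (0.31 log units; beyond the scatter). Where the methoxy sits also matters, as 4-methoxyphenyl in place of 3-methoxyphenyl gives an at least 2.0-fold lower number from compound 3 to compound 4 (0.31 log units; beyond the scatter). These sizes are only minimums, because the other compounds stop at an assay limit: the limit of > 50000 nM in this assay, at which 3 of the 4 values shown sit.

Still open, on these data alone, is whether ethoxy, hydroxyl or an amine at this same place would lower the number further.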